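The source may report more compounds than this note shows. Statements on the series, on what has been measured and on what is new or still open speak of the compounds shown alone.

Measured so far:
compound 1 `COc1cc2c(cc1OC)C(=O)/C(=C/c1cc(C)c(N)c(C)c1)C2`: 55 nM
compound 2 `COc1cc2c(cc1OC)C(=O)/C(=C/c1cc(C)c(OC(C)=O)c(C)c1)C2`: 400 nM

In a functional assay on Jurkat cells (Homo sapiens) for antiproliferative activity, read by MTT assay (on this read-out lower numbers stand for stronger inhibition and higher numbers for weaker inhibition), compound 1 gives the lower of these two numbers, and the step of a 7.3-fold higher number from compound 1 to compound 2 (0.86 log units; beyond the scatter) lies beyond the scatter. Compound 3 `COc1cc2c(c(N)c1OC)C(=O)/C(=C/c1cc(C)c(N)c(C)c1)C2` differs from compound 1 by amino in place of hydrogen on an aromatic carbon. For the measured compounds named here, the only measured step, the one just named, alters a group on a different part of the molecule, so it does not bear on this change; no directly comparable step exists. On that basis no step beyond the scatter is expected, which means an estimated 1.5-fold higher number from compound 1 to compound 3 (0.16 log units; within the scatter). For compound 3 the estimate is 80 nM, with a range from 20 nM to 400 nM.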

Compound 3, half-maximal inhibitory concentration: 23.5 nM
Compound 3: the middle estimate sits 3.4-fold (0.53 log units) above what was measured, within the range that was stated.
By their numbers in this assay, from the lowest: compound 3; then compound 1; then compound 2.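

In this assay, amino in place of hydrogen on the aromatic carbon ortho to a fused ring and ortho to a methoxy group gives a 2.3-fold lower number from compound 1 to compound 3 (0.37 log units; beyond the scatter) and so a modest gain. This shows that this carbon of the shared core can carry a new group without losing activity, which the earlier change on another part of the molecule could not show. Nothing measured here gives a reason for the shift. On these data alone, whether the gain is specific to amino remains open, since a hydroxyl group, a fluorine atom or a dimethylamino group at this carbon would test that. Also open, as far as these compounds go, is whether it would persist with the acetoxy group of compound 2 on the other ring.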